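This account rests on a few compounds, and the source may have more. Where it says the series, first, only, none or still open, it means among the compounds named here.

Three compounds share one core and differ only in the aryl group attached to it. Compound 1 `O=C(NO)c1ccc(NCc2nc(-c3ccc(Br)cc3)nn2-c2ccccc2)cc1` carries a 4-bromophenyl group, and in an assay on Sf9 cells for inhibition of protein deacetylase HDAC6 (Homo sapiens), read by fluorescence, with a stated time of 40 min, tested at 100 nM (on this read-out higher numbers stand for more inhibition at the one concentration tested (going by the name of the read-out) and lower numbers for less inhibition), compound 1 gives 54.7%. Compound 2 `O=C(NO)c1ccc(NCc2nc(-c3ccco3)nn2-c2ccccc2)cc1`, with furan-2-yl in that place, gives 59.9% in this assay, and the step of a number 5.2 percentage points higher from compound 1 to compound 2 (within the scatter) lies within the scatter. Compound 3 `O=C(NO)c1ccc(NCc2nc(-c3ccc(Cl)c(Cl)c3)nn2-c2ccccc2)cc1`, bearing 3,4-dichlorophenyl, gives 34.5% and stands lowest of the three numbers, with a number 20.2 percentage points lower from compound 1 to compound 3 (beyond the scatter) and a number 25.4 percentage points lower from compound 2 to compound 3 (beyond the scatter) both beyond the scatter.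

Compound 4 `O=C(NO)c1ccc(NCc2nc(-c3ccc(Cl)cc3)nn2-c2ccccc2)cc1` differs from compound 3 by hydrogen in place of chloro on an aromatic carbon, so that 3,4-dichlorophenyl becomes 4-chlorophenyl. The two steps that bear on this, a number 20.2 percentage points lower from compound 1 to compound 3 (beyond the scatter) and a number 25.4 percentage points lower from compound 2 to compound 3 (beyond the scatter), are the moves from another aryl group to the dichlorophenyl of compound 3, each modest in size. Because compound 1 gives 54.7% with a 4-bromophenyl group resembling 4-chlorophenyl, compound 4 is expected to move back by a comparable amount. The expected step is a number 17.5 percentage points higher from compound 3 to compound 4 (beyond the scatter) in this assay. Compound 4 is therefore estimated at 52%, in the range 36% to 68%.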

Compound 4, a percentage reported as inhibition, at one concentration (the size of the read-out at that concentration, not a potency): 67.2%
Compound 4: middle estimate off by 15.2 percentage points, on the low side, and the stated range covers the measured number.
By their numbers in this assay, from the lowest: compound 3; then compounds 1, 2 and 4 (each within the scatter of the next, the first and the last beyond it).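

In this assay, removing a single chloro from the 3,4-dichlorophenyl group gives a large step, a number 32.7 percentage points higher from compound 3 to compound 4 (beyond the scatter), so this one atom separates compound 3 from the rest of the set. Among the compounds shown here, the halogen left on the ring also counts: chloro in place of bromo gives a number 12.5 percentage points higher from compound 1 to compound 4 (beyond the scatter), the first step here that compares two halogens directly. By contrast, 4-chlorophenyl and furan-2-yl cannot be told apart, at a number 7.3 percentage points higher from compound 2 to compound 4 (within the scatter), so a six-membered aryl group with the right substituent serves as well here as the furan.

No evidence is at hand that accounts for any of these steps. It remains open how a fluoro, a methoxy or an amine in place of chloro on this phenyl ring would read, and whether the order among these compounds holds for any other deacetylase.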